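Alkylamino series: isopropyl to cyclopropyl on the shared core

A few compounds are considered here, and "the series" means these few. Any claim that something is new, unique, unknown or untested is made for them only; others in the source may bear on it.

Measured in a functional assay on aorta (Rattus norvegicus) for inhibition; on this read-out higher numbers stand for an effect only at larger amounts of compound and lower numbers for an effect already at smaller amounts:
- compound 1 `CCCNC1=NS(=O)(=O)c2ccc(Cl)cc2N1`: 73200 nM
- compound 2 `CC(C)NC1=NS(=O)(=O)c2ccc(Cl)cc2N1`: 53400 nM

Not yet measured:
- compound 3 `O=S1(=O)N=C(NC2CC2)Nc2cc(Cl)ccc21`

In this assay compound 2, at 53400 nM, stands level with compound 1 within the scatter. Compound 3 keeps the shared core and changes one group: cyclopropyl in place of isopropyl on an amine nitrogen. In words, this is cyclopropyl in place of isopropyl on an amine nitrogen.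

Among the compounds with values here, only one measured step bears on this change. It is the exchange of isopropyl for propyl at the same amine nitrogen, a 1.4-fold lower number from compound 1 to compound 2 (0.14 log units; within the scatter). Within the data shown here, no measured compound yet carries a ring at this place, so the evidence is thin and no direction can be read from it. On this single step, no shift beyond the scatter is expected in this assay. The expected step is a 1.1-fold lower number from compound 2 to compound 3 (0.03 log units; within the scatter). For compound 3 the estimated value is 50000 nM, with an expected range from 20000 nM to 130000 nM.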

Compound 3, half-maximal effective concentration: 156000 nM
Beside the measured number, compound 3's estimate is 3.1-fold (0.49 log units) below it; measured number outside the range, above it.
By their numbers in this assay, from the lowest: compounds 2 and 1 (each within the scatter of the next); then compound 3.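

In this assay the amine nitrogen now shows a response to the group it carries: propyl and isopropyl stood level within the scatter, while cyclopropyl brings a 2.9-fold higher number from compound 2 to compound 3 (0.47 log units; beyond the scatter) and a 2.1-fold higher number from compound 1 to compound 3 (0.33 log units; beyond the scatter) as modest steps. Isopropyl and cyclopropyl have the same count of carbons, so the step from compound 2 to compound 3 goes with the entry of the ring and not with any change in the number of heavy atoms. Compound 3 therefore needs the largest amount of compound of the three for its effect, and no measurement at hand accounts for this step.

On these data alone, whether the rise belongs to rings at this nitrogen in general or only to the three-membered ring stays open, and a cyclobutyl or cyclopentyl group at the same place would separate the two. How far the open-chain level holds also remains unsettled, since only propyl and isopropyl define it, and an ethyl group or a longer chain such as butyl would show whether that level extends beyond these two.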